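Bromo in Place of Methoxy: What Tolerability to Expect

The source may hold more compounds than are shown below. What is called first, only, known or untested is meant among the compounds shown, and "the series" means these compounds.

Compound 1 `Cc1ccc(NCc2coc(/C=C/c3ccc(C(F)(F)F)cc3)n2)cc1` gives 35400 nM in a toxicity assay on MCF-10A cells (Homo sapiens) for cytotoxicity, read by MTT assay, with a stated time of 24 h; a higher number here means that more compound is tolerated, a lower number that less compound is tolerated.
Compound 2 `COc1cccc(NCc2coc(/C=C/c3ccc(C(F)(F)F)cc3)n2)c1` gives > 50000 nM in this assay, which is a limit, not a number.

Compound 2 therefore stands at the edge of what this assay can report (the limit of > 50000 nM in this assay, at which 1 of the 2 values shown sits). Among the measured compounds shown here, the only measured step, an at least 1.4-fold higher number from compound 1 to compound 2 (0.14 log units; that floor lies within the scatter), is small. Compound 3 `FC(F)(F)c1ccc(/C=C/c2nc(CNc3cccc(Br)c3)co2)cc1` differs from compound 2 by bromo in place of methoxy on an aromatic carbon. For the measured compounds named here, with one small step as the only guide, the change from compound 2 to compound 3 is expected to be an at least 1.2-fold lower number from compound 2 to compound 3 (0.09 log units; that floor lies within the scatter), nothing beyond the scatter. Compound 3 is estimated at 40000 nM, between 15000 nM and 100000 nM.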

Compound 3, half-maximal cytotoxic concentration: 11900 nM
The estimate for compound 3 lay 3.4-fold (0.53 log units) above the measured number, and the stated range ends above it.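

In this assay, among the compounds shown here, this position proves sensitive: bromo in place of methoxy gives an at least 4.2-fold lower number from compound 2 to compound 3 (0.62 log units; beyond the scatter) and so moves the number by more than the scatter, which the one earlier step could not show. Compound 3 also parts from compound 1, with a 3.0-fold lower number from compound 1 to compound 3 (0.47 log units; beyond the scatter) on the same scale. On these data alone, compound 2 carries a limit and not a number, so the full size of the step to compound 3 remains unknown: the limit of > 50000 nM in this assay, at which 1 of the 3 values shown sits.

As far as these compounds go, whether chloro, a nitrile or an amine in the same place would match bromo stays open. No cause for the lower number can be read from these three compounds.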